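This account rests on a few compounds, and the source may have more. Where it says the series, first, only, none or still open, it means among the compounds named here.

Compound 1 `CCCC(=O)Nc1ncc(-c2ccc(OC)cc2)n1C` gives > 100000 nM in a toxicity assay on THP-1 cells (Homo sapiens) for inhibition (on this read-out higher numbers stand for lower toxicity in this test and lower numbers for higher toxicity in this test), a limit. Compound 2 `COc1ccc(-c2cnc(NC(=O)c3ccccc3C)n2C)cc1` gives > 100000 nM, also a limit. Compound 3 `COc1ccc(-c2cnc(NC(=O)c3cccc(Cl)c3)n2C)cc1` gives > 28000 nM, again a limit.

Compound 3 therefore stands at the limit of > 28000 nM in this assay, at which 1 of the 3 values shown sits. Compounds 1 and 2 sit at the limit of > 100000 nM in this assay, at which 2 of the 3 values shown sit. For the measured compounds named here, no compound can be placed above or below another on these numbers.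

Compound 4 `COc1ccc(-c2cnc(NC(=O)C3CCOCC3)n2C)cc1` differs from compound 3 in that (oxan-4-yl in place of 3-chlorophenyl on a carbonyl carbon). Going by the values given here, the steps that bear on this exchange at the carbonyl carbon are a step that the two limits leave unreadable from compound 1 to compound 3, a step that the two limits leave unreadable from compound 2 to compound 3 and a step that the two limits leave unreadable from compound 1 to compound 2; all three are unreadable, since every value shown is a limit. No step beyond the scatter can be foreseen in either direction, and another limit is the most likely outcome. Compound 4 is expected to give 100000 nM, with a range from 30000 nM to 300000 nM. The step this estimate implies is a step that the limit leaves unreadable from compound 3 to compound 4.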

Compound 4, half-maximal cytotoxic concentration: > 100000 nM
Compound 4 was reported as a limit (the forecaster's own chance of this, stated with the estimate: 85%); the middle value sits exactly at the limit.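

For the compounds shown here, the result for compound 4 in this assay is a limit, as are those for compounds 1, 2 and 3, so no step from any of them to compound 4 can be read. The compounds shown leave open whether any group on the carbonyl carbon would give a value that is not a limit.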